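Working notes: from compound 1 to compound 4

The compounds below may be only part of what the source reports. "The series", "measured", "known", "first", "only" and "open" are said of these compounds alone.

Measured so far in an ADME assay on microsomes from liver (Homo sapiens) for metabolic stability, read by LC-MS, using NADPH, with stated times of 5 min and 30 min, tested at 1 uM; on this read-out lower numbers stand for slow clearance and higher numbers for fast clearance
- compound 1 `O=C(Nc1ccccc1)c1cnc(NCc2c(F)ccc3c2CCO3)n2cnnc12` gives 14 mL.min-1.g-1
- compound 2 `Cn1nccc1-c1cnc(NCc2c(F)ccc3c2CCO3)c2cn[nH]c(=O)c12` gives 14 mL.min-1.g-1
- compound 3 `Cc1ncccc1-c1cnc(NCc2c(F)ccc3c2CCO3)c2cn[nH]c(=O)c12` gives 41 mL.min-1.g-1

Compound 1 stands level with compound 2 at the digits shown, and together they hold the lowest of the three numbers. Compound 3 is the furthest from compound 1, and that gap lies beyond the scatter.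

Compound 4 `CN(c1ccccc1)c1cnc(NCc2c(F)ccc3c2CCO3)n2cnnc12` is still unmeasured. It carries methyl(phenyl)amino in place of phenylcarbamoyl on an aromatic carbon and keeps the rest of compound 1 unchanged. For the measured compounds named here, no measured compound carries methyl(phenyl)amino, so the direction of this change has not been observed.

Going by the values given here, the only measured step in one place is a 2.9-fold higher number from compound 2 to compound 3 (0.47 log units; beyond the scatter) and it is modest. It exchanges other groups on another core, so it suggests a size for the step but not a direction. A modest rise is the working expectation, given that compound 1 at 14 mL.min-1.g-1 sits at the low end of the three numbers. The estimated step is a 1.7-fold higher number from compound 1 to compound 4 (0.23 log units; within the scatter) and it may well prove to lie within the scatter. In this assay the estimate for compound 4 is 24 mL.min-1.g-1 with an expected range from 11 mL.min-1.g-1 to 50 mL.min-1.g-1.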

Compound 4, intrinsic clearance in microsomes: 55 mL.min-1.g-1
Compound 4: the middle estimate sits 2.3-fold (0.36 log units) below what was measured; measured number outside the range, above it.
By their numbers in this assay, from the lowest: compounds 1 and 2 (each within the scatter of the next); then compounds 3 and 4 (each within the scatter of the next).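

At this position, an aromatic carbon of the six-membered aromatic ring with 2 nitrogen, the exchange of phenylcarbamoyl for methyl(phenyl)amino now has an observed direction in this assay: a 3.9-fold higher number from compound 1 to compound 4 (0.59 log units; beyond the scatter). The earlier step lay on another core and exchanged other groups, so only this result shows that the read-out on the core of compound 1 responds to the group at this carbon, even with the phenyl ring retained on both sides of the exchange. Nothing at hand explains the rise.

The exchange removes the carbonyl and the hydrogen-bond donor and adds the methyl in a single step, so the compounds shown leave open which of these differences carries it; a phenylamino group at the same carbon, with the hydrogen kept on the nitrogen, would separate the methyl from the loss of the carbonyl. Also open, going by these compounds, is whether a morpholine at this carbon, with no phenyl ring, would stay near the number of compound 4 at 55 mL.min-1.g-1 or come back towards that of compound 1 at 14 mL.min-1.g-1.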